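The compounds below may be only part of what the source reports. "The series", "measured", "known", "first", "only" and "open" are said of these compounds alone.

Compound 1 `Cn1cncc1CN1CC(N(CC2CCN(C(=O)CC(F)(F)F)CC2)S(=O)(=O)c2ccccn2)Cc2cc(C#N)ccc21` gives 0.5 10^-6 cm/s in an ADME assay on Caco-2 cells (Homo sapiens) for permeability, in the apical to basolateral direction; on this read-out higher numbers stand for higher permeability and lower numbers for lower permeability.
Compound 2 `Cn1cncc1CN1CC(N(CC2CCN(C(=O)C3CC3)CC2)S(=O)(=O)c2ccccn2)Cc2cc(C#N)ccc21` gives 0.5 10^-6 cm/s in this assay.
Compound 3 `Cn1cncc1CN1CC(N(CC2CCN(C(=O)N3CCCC3)CC2)S(=O)(=O)c2ccccn2)Cc2cc(C#N)ccc21` gives 0.6 10^-6 cm/s in this assay.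

Compound 2 stands level with compound 1, the two together being the lowest of the three numbers, and the step of a 1.2-fold higher number from compound 2 to compound 3 (0.08 log units; within the scatter) lies within the scatter, so all three compounds sit at about the same permeability.

Compound 4 `Cn1cncc1CN1CC(N(CC2CCN(S(=O)(=O)c3ccccc3)CC2)S(=O)(=O)c2ccccn2)Cc2cc(C#N)ccc21` is the unmeasured compound. It differs from compound 2 by phenylsulfonyl in place of cyclopropylcarbonyl on an amine nitrogen in a ring.

The measured steps all swap one group for another on a carbonyl carbon: no change at the digits printed from compound 1 to compound 2 (within the scatter), a 1.2-fold higher number from compound 1 to compound 3 (0.08 log units; within the scatter) and a 1.2-fold higher number from compound 2 to compound 3 (0.08 log units; within the scatter), none of them beyond the scatter. None of these steps replaces the carbonyl itself by a sulfonyl, so the change to compound 4 is not covered directly. With every known change at this position leaving the number flat, no step beyond the scatter is expected in this assay for compound 4, and a 1.2-fold higher number from compound 2 to compound 4 (0.08 log units; within the scatter) is the expected step.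

Compound 4 is therefore estimated at 0.6 10^-6 cm/s in this assay, with a range from 0.3 10^-6 cm/s to 1.2 10^-6 cm/s.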

Compound 4, apparent permeability: 0.1 10^-6 cm/s
Estimate against measurement, compound 4: 6.0-fold (0.78 log units) above; measured number below the stated range.
By their numbers in this assay, from the lowest: compound 4; then compounds 1, 2 and 3 (each within the scatter of the next).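

The position on the ring nitrogen stayed flat while only the group on the carbonyl changed, but it responds once a phenylsulfonyl takes the place of the carbonyl group: in this assay the new steps read a 5.0-fold lower number from compound 2 to compound 4 (0.70 log units; beyond the scatter) and a 6.0-fold lower number from compound 3 to compound 4 (0.78 log units; beyond the scatter) and a 5.0-fold lower number from compound 1 to compound 4 (0.70 log units; beyond the scatter). The level numbers of compound 1, compound 2 and compound 3 therefore held only among carbonyl-linked groups and do not extend to every group on this nitrogen. No measurement here accounts for the drop.

Two things change together in compound 4, the carbonyl giving way to a sulfonyl and the group it carries becoming a phenyl ring, so the compounds shown cannot separate them. A methylsulfonyl group or a benzoyl group on the same nitrogen would pull these two changes apart.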